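Swapping Methoxy for Fluoro on the Cinnamoyl Aryl

The compounds below may be only part of what the source reports. "The series", "measured", "known", "first", "only" and "open" are said of these compounds alone.

Measured compounds:
- compound 1, `O=C(/C=C/c1ccc(F)cc1)Nc1nnc(-c2ccccc2)s1`: 1.45 ug/mL
- compound 2, `Cc1ccc(-c2nnc(NC(=O)/C=C/c3ccc(F)cc3)s2)cc1`: 1.27 ug/mL
- compound 3, `COc1ccc(/C=C/C(=O)Nc2nnc(-c3ccc(OC)cc3)s2)cc1`: 0.28 ug/mL

In a functional assay on MCF7 cells (Homo sapiens) for antiproliferative activity, read by MTT assay, with a stated time of 48 h (a higher number here means a weaker inhibitor, a lower number a stronger inhibitor), compound 3 stands at the lowest number of the three, and its gaps to compound 2 and to compound 1 both lie beyond the scatter. Compound 4, `COc1ccc(-c2nnc(NC(=O)/C=C/c3ccc(F)cc3)s2)cc1`, is the unmeasured partner of compound 3. The change from compound 3 to compound 4 is fluoro in place of methoxy on an aromatic carbon. Among the compounds with values here, the only measured step, a 1.1-fold lower number from compound 1 to compound 2 (0.06 log units; within the scatter), sits on the other aryl ring and tells nothing about this exchange. Within the data shown here, compound 4 also relates to compound 2 by a methoxy in place of methyl on the thiadiazole aryl, a pair for which the two values show a gap but no single-point step has been measured. Among the measured compounds shown here, with no direct precedent, the change in this assay is expected to move the number toward the fluorophenyl compounds 1 and 2, though how far is uncertain. For compound 4 the estimate is 0.7 ug/mL, between 0.3 ug/mL and 1.6 ug/mL, an expected step of a 2.5-fold higher number from compound 3 to compound 4 (0.40 log units; beyond the scatter).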

Compound 4, half-maximal inhibitory concentration: 0.85 ug/mL
Estimate against measurement, compound 4: 1.2-fold (0.08 log units) below; the measured number falls inside the stated range.
By their numbers in this assay, from the lowest: compound 3; then compounds 4, 2 and 1 (each within the scatter of the next).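

In this assay, the exchange of 4-methoxyphenyl to 4-fluorophenyl gives a 3.0-fold higher number from compound 3 to compound 4 (0.48 log units; beyond the scatter), the first step measured on this ring, and it shows that the methoxy here matters when the methoxy on the other aryl ring stays in place. With fluoro kept on this ring, a 1.5-fold lower number from compound 2 to compound 4 (0.17 log units; within the scatter) and a 1.7-fold lower number from compound 1 to compound 4 (0.23 log units; within the scatter) both lie within the scatter, so a methoxy on the other aryl ring alone does not set compound 4 apart from compound 1 or compound 2. No available evidence accounts for the effect of this exchange.

On these data alone, whether the methoxy on this ring has the same effect with hydrogen or methyl on the other aryl ring remains open. So does the outcome of placing an amine, a hydroxyl or an ethoxy chain at this position.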